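Hydroxamic Acid Carrier: Benzyl Replaced by Pyrimidinyl

This account rests on a few compounds, and the source may have more. Where it says the series, first, only, none or still open, it means among the compounds named here.

Three compounds share one core and have been measured in a functional assay on A549 cells (Homo sapiens) for antiproliferative activity, read by CCK-8 assay, with a stated time of 72 h; a lower number here means a stronger inhibitor, a higher number a weaker inhibitor:

Compound 1 `CCOc1cc(C(C)(C)C)ccc1C1=NC(c2ccc(Cl)cc2)C(c2ccc(Cl)cc2)N1C(=O)N1CCN(Cc2ccc(C(=O)NO)cc2)CC1` gives 2170 nM.
Compound 2 `CCOc1cc(C(C)(C)C)ccc1C1=NC(c2ccc(Cl)cc2)C(c2ccc(Cl)cc2)N1C(=O)NCCCCCCC(=O)Nc1ccccc1N` gives 16000 nM.
Compound 3 `CCOc1cc(C(C)(C)C)ccc1C1=NC(c2ccc(Cl)cc2)C(c2ccc(Cl)cc2)N1C(=O)NCCCCCCCC(=O)Nc1ccccc1N` gives 15200 nM.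

Compound 1 stands lowest of the three and is the strongest inhibitor here, its distance to compound 2 and to compound 3 lying well beyond the scatter. Compound 2 and compound 3 differ only in chain length, and the step of a 1.1-fold lower number from compound 2 to compound 3 (0.02 log units; within the scatter) shows that this lengthening changes nothing that can be trusted.

Compound 4 `CCOc1cc(C(C)(C)C)ccc1C1=NC(c2ccc(Cl)cc2)C(c2ccc(Cl)cc2)N1C(=O)N1CCN(c2ncc(C(=O)NO)cn2)CC1` keeps the core and the ring amine of compound 1 and alters only the arm that carries the hydroxamic acid: 5-(hydroxycarbamoyl)pyrimidin-2-yl in place of 4-(hydroxycarbamoyl)benzyl on an amine nitrogen in a ring. Going by the values given here, none of the measured steps bears on this exchange. Among the compounds with values here, the single measured step concerns a chain in a different part of the molecule, and no pair among compound 1, compound 2 and compound 3 varies the group on the ring amine. The expectation for compound 4 therefore rests on compound 1 alone, with a step of a 1.1-fold lower number from compound 1 to compound 4 (0.04 log units; within the scatter) that is expected to stay within the scatter, in no firm direction. Compound 4 is estimated at 2000 nM, with a range from 600 nM to 7000 nM.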

Compound 4, half-maximal inhibitory concentration: 1970 nM
Compound 4: the middle estimate sits 1.0-fold (0.01 log units) above what was measured, within the range that was stated.
By their numbers in this assay, from the lowest: compounds 4 and 1 (each within the scatter of the next); then compounds 3 and 2 (each within the scatter of the next).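

In this assay, replacing 4-(hydroxycarbamoyl)benzyl with 5-(hydroxycarbamoyl)pyrimidin-2-yl on the amine nitrogen in the ring gives a step that cannot be told apart from repeat-measurement noise (a 1.1-fold lower number from compound 1 to compound 4 (0.04 log units; within the scatter)). Going by these compounds alone, this is the first direct look at this position, and it shows that the position tolerates a real rewrite of the arm: a six-membered aromatic ring of carbon only gives way to one with 2 hetero atoms, and the hydrogen-bond acceptors go from 2 to 4, yet the two compounds read alike. Nothing measured alongside these numbers explains why such different arms give matching values.

On these data alone, only these two arms have been compared at this position, both ending in the same hydroxycarbamoyl group, so it remains open whether the match would hold for a longer chain linking the ring amine to the aromatic ring. As far as these compounds go, it is equally open how a carboxylic acid or a primary amide in place of the hydroxycarbamoyl group on the 5-position of the pyrimidine would read in this assay.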